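A few compounds are considered here, and "the series" means these few. Any claim that something is new, unique, unknown or untested is made for them only; others in the source may bear on it.

Compound 1 `COc1cc(C)cc(-c2c(-c3ccnc(-c4ccc(C(C)=O)cc4)c3)cnn2CC#N)c1` is tested in a functional assay on A498 cells (Homo sapiens) for cytotoxicity, read by sulforhodamine B assay, with a stated time of 48 h, tested at 100 nM (a higher number here means a weaker effect of the compound at the concentration tested, a lower number a stronger effect), where it gives 65%. This is the highest of the three numbers shown, meaning the weakest effect. Compound 2 `COc1cc(C)cc(-c2nn(CC#N)cc2-c2ccc(-c3cccc(C(C)=O)c3)nc2)c1` gives 53% in this assay, and compound 3 `COc1cc(C)cc(-c2nn(CC#N)cc2-c2ccnc(-c3ccc(N(C)C)cc3)c2)c1` gives -8%, both lower than compound 1 by more than the scatter. Compound 4 `COc1cc(C)cc(-c2c(-c3ccnc(-c4ccc(N(C)C)cc4)c3)cnn2CC#N)c1` has not yet been measured. It differs from compound 1 in one place: dimethylamino in place of acetyl on an aromatic carbon. Compound 3, which also carries a dimethylamino group, shows a far lower number than compound 1, though its core is built differently, so this is only a pointer. A sizeable step downward, well beyond the scatter, is expected in this assay, a number 50 percentage points lower from compound 1 to compound 4 (beyond the scatter). Compound 4 is therefore estimated at 15%, with a likely range from -15% to 45%.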

Compound 4, a percentage reported as activity, at one concentration (the size of the read-out at that concentration, not a potency): 10%
Compound 4: middle estimate off by 5 percentage points, on the high side, and the stated range covers the measured number.
By their numbers in this assay, from the lowest: compound 3; then compound 4; then compound 2; then compound 1.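

With the core of compound 1 unchanged, replacing 4-acetylphenyl with 4-(dimethylamino)phenyl gives a large step in this assay, a number 55 percentage points lower from compound 1 to compound 4 (beyond the scatter), so the group at this place strongly shapes the read-out. The two groups have the same heavy-atom and hydrogen-bond acceptor counts, so those counts do not separate them. No measurement shown here explains the size of this step. Open, going by these compounds, is how a carboxylic acid or a morpholine at this place would compare with dimethylamino. Also open, on these data alone, is whether the same change gives a similar step on a different core.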